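The source may hold more compounds than are shown below. What is called first, only, known or untested is meant among the compounds shown, and "the series" means these compounds.

Working notes on the series.

Compound 1 `Nc1cc(N)c2nc(-c3ccccc3)c(Oc3ccc(Cl)c(Cl)c3)nc2c1` is one of two compounds with a number in a functional assay on SF-539 cells (Homo sapiens) for inhibition, read by sulforhodamine B assay, with a stated time of 48 h (on this read-out lower numbers stand for stronger inhibition of growth and higher numbers for weaker inhibition of growth), and there compound 1 gives 13500 nM. The other measured compound is compound 2 `COc1ccc(CNc2nc3cc(N)cc(N)c3nc2-c2ccccc2)cc1OC`, which in this assay gives 20000 nM. The two numbers lie within the usual scatter of each other, so compound 1 and compound 2 cannot be told apart on this read-out; compound 1 merely has the lower of the two figures. Among the measured compounds shown here, no pair of measured compounds differing in a single place is available, so no measured step is known for the shared core.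

Compound 3 `Nc1cc(N)c2nc(-c3ccccc3)c(Oc3ccc(F)cc3)nc2c1` is the next compound to be measured. Relative to compound 1 the change is 4-fluorophenyl in place of 3,4-dichlorophenyl on an oxygen on an aromatic ring. Nothing measured shows what this exchange does on this read-out. The expectation is therefore cautious: the step of a 1.6-fold higher number from compound 1 to compound 3 (0.21 log units; within the scatter) is estimated to stay within or only slightly beyond the scatter, with a weakening of growth inhibition held the more likely direction. Compound 3 is expected to give about 22000 nM in this assay, plausibly between 8000 nM and 60000 nM.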

Compound 3, concentration for 50% growth inhibition: 18200 nM
Compound 3: the middle estimate sits 1.2-fold (0.08 log units) above what was measured; the measured number falls inside the stated range.
By their numbers in this assay, from the lowest: compounds 1, 3 and 2 (each within the scatter of the next).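

Among the compounds shown here, the exchange of 3,4-dichlorophenyl for 4-fluorophenyl on an oxygen on an aromatic ring gives the first measured step at this position, with a 1.3-fold higher number from compound 1 to compound 3 (0.13 log units; within the scatter) in this assay, so the two groups cannot be told apart on this read-out. Removing both chlorine atoms and introducing a fluorine atom, with the ring and the oxygen kept, therefore produces no readable difference in growth inhibition at this position in this pair. No measured information on the series bears on why this step is so small.

This single pair leaves open whether any replacement at this position can move the number beyond the scatter, for example an unsubstituted phenyl, a phenyl carrying a carboxylic acid or a dimethylamino group, or a longer alkyl chain on the oxygen in place of the aromatic ring. It also leaves open whether chlorine or fluorine alone accounts for any part of the step, since the two halogen patterns are exchanged together and a 4-chlorophenyl group would be needed to separate them.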